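This account rests on a few compounds, and the source may have more. Where it says the series, first, only, none or still open, it means among the compounds named here.

Measured so far:
- compound 1, `CC(O)(C(=O)Nc1ccc(S(=O)(=O)c2ccccc2F)cc1)C(F)(F)F`: 1300 nM
- compound 2, `Cc1cc(NC(=O)C(C)(O)C(F)(F)F)ccc1S(=O)(=O)c1ccccc1`: 1600 nM

Both compounds were tested in a functional assay (Cavia porcellus) with sulfonylurea receptors; K-ATP channels (Homo sapiens) as the target; a lower number here means a stronger inhibitor, a higher number a weaker inhibitor. Compound 1 gives 1300 nM, and compound 2 gives 1600 nM. Compound 1 has the lowest of the two numbers, but the gap to compound 2 is within the scatter of repeated measurements, so the two cannot be told apart on these data.

The next compound, compound 3 with the structure `CC(O)(C(=O)Nc1ccc(S(=O)(=O)c2ccc(Br)cc2)cc1)C(F)(F)F`, differs from compound 1 at one place: 4-bromophenyl in place of 2-fluorophenyl on a sulfonyl sulfur. The trifluoromethyl, the hydroxyl, the amide and the shared core are unchanged.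

Among the compounds with values here, no measured pair in this set isolates a change of this kind, so there is no step on which to rest a firm expectation. The exchange keeps the size of the group and its lack of donors and acceptors, and I expect compound 3 to land near compound 1, with a step from compound 1 to compound 3 of a 1.2-fold lower number from compound 1 to compound 3 (0.07 log units; within the scatter), most likely no larger than the scatter. In this assay compound 3 is therefore estimated at 1100 nM, within a range from 350 nM to 3500 nM.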

Compound 3, half-maximal inhibitory concentration: > 30000 nM
Compound 3 was reported as a limit; the forecaster's own chance of this, stated with the estimate: 5%; middle value at least 27-fold (1.43 log units) away from the limit.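

In this assay, compound 3 gives > 30000 nM, which is a limit of the assay and not a number. Putting 4-bromophenyl in place of 2-fluorophenyl on a sulfonyl sulfur gives an at least 23-fold higher number from compound 1 to compound 3 (1.36 log units; beyond the scatter), so this position is far from indifferent to the exchange, even though the two groups match in everything counted here: heavy atoms, hydrogen-bond donors, hydrogen-bond acceptors and net charge. That sameness therefore does not predict the outcome at this position, and the step can be read only as a minimum, with no exact size: the limit of > 30000 nM in this assay, at which 1 of the 3 values shown sits.

The compounds shown leave open whether the loss follows the change of halogen from fluorine to bromine or the change of its place on the ring, since both differ at once between compound 1 and compound 3. A 4-fluorophenyl group and a 2-bromophenyl group on the same sulfonyl sulfur would pull these two changes apart, and they would also show whether any group with a halogen in the 4-position can keep a measurable value in this assay.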